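The compounds below may be only part of what the source reports. "The series", "measured", "known", "first", "only" and "open" are said of these compounds alone.

Measured in a functional assay on HT-29 cells (Homo sapiens) for cytotoxicity, read by MTT assay; on this read-out lower numbers stand for stronger inhibition and higher numbers for weaker inhibition:
compound 1 `C=C1C(=O)[C@]23C[C@@]1(Cl)CC[C@H]2[C@@]12C=CC(=O)[C@](C)(C(=O)O1)[C@H]2[C@@H]3C(=O)OC`: 2900 nM
compound 2 `C=C1C(=O)[C@]23C[C@@]1(Cl)CC[C@H]2[C@@]12C=CC(=O)[C@](C)(C(=O)O1)[C@H]2[C@@H]3C(=O)OCc1ccccc1`: 4500 nM
compound 3 `C=C1C(=O)[C@]23C[C@@]1(I)CC[C@H]2[C@@]12C=CC(=O)[C@](C)(C(=O)O1)[C@H]2[C@@H]3C(=O)OCc1ccccc1`: 50200 nM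

Compound 1 sits at the low end of these numbers, and compound 3 stands well clear of it. The nearest gap is a 1.6-fold higher number from compound 1 to compound 2 (0.19 log units; within the scatter), and that change lies elsewhere in the molecule, so it says little here.

Compound 4 `C=C1C(=O)[C@]23C[C@@]1(OCC)CC[C@H]2[C@@]12C=CC(=O)[C@](C)(C(=O)O1)[C@H]2[C@@H]3C(=O)OC` carries ethoxy in place of chloro on a saturated ring carbon.

The only measured replacement of chloro at that carbon is an 11-fold higher number from compound 2 to compound 3 (1.05 log units; beyond the scatter). On that evidence a higher number is expected in this assay, though a smaller rise, as ethoxy itself remains unmeasured. The expected change is a 2.8-fold higher number from compound 1 to compound 4 (0.44 log units; beyond the scatter). Compound 4 is estimated at 8000 nM, with an expected range of 2500 nM to 30000 nM.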

Compound 4, half-maximal inhibitory concentration: 34100 nM
The estimate for compound 4 lay 4.3-fold (0.63 log units) below the measured number, outside the stated range (above it).
By their numbers in this assay, from the lowest: compounds 1 and 2 (each within the scatter of the next); then compounds 4 and 3 (each within the scatter of the next).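

At this saturated ring carbon, ethoxy in place of chloro gives a 12-fold higher number from compound 1 to compound 4 (1.07 log units; beyond the scatter) in this assay, so the large rise is no longer confined to iodo, which gave an 11-fold higher number from compound 2 to compound 3 (1.05 log units; beyond the scatter). In both pairs, the compound carrying chloro has the lower number, although each replacement was made with a different group on a different parent compound. Nothing measured here explains why either replacement has this effect. The compounds shown leave open how fluoro, bromo, hydroxy or an amine at this carbon would compare with chloro, and whether methoxy or a longer chain would behave like ethoxy.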